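The source may report more compounds than this note shows. Statements on the series, on what has been measured and on what is new or still open speak of the compounds shown alone.

Measured so far:
- compound 1, `O=C1/C(=C/c2ccccc2C(F)(F)F)CCc2c(O)cccc21`: 3830 nM in a functional assay on RAW264.7 cells (Mus musculus) for inhibition; a lower number here means a stronger inhibitor, a higher number a weaker inhibitor
- compound 2, `O=C1/C(=C/c2cccc(C(F)(F)F)c2)CCc2c(O)cccc21`: 1970 nM in this assay

Compound 1 has the higher number of the two, but compound 2 gives a value within the usual scatter of it, so the two cannot be told apart. Compound 3, `O=C1/C(=C/c2ccccc2Cl)CCc2c(O)cccc21`, is still unmeasured; it differs from compound 1 in one place: chloro in place of trifluoromethyl on an aromatic carbon. Among the compounds with values here, no measured pair shows what this swap does to the numbers in this assay. With nothing to go on beyond this pair, the step from compound 1 to compound 3 is expected to stay within the scatter, a 1.3-fold lower number from compound 1 to compound 3 (0.11 log units; within the scatter). Compound 3 is therefore estimated at 3000 nM, between 1200 nM and 7500 nM.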

Compound 3, half-maximal inhibitory concentration: 1280 nM
Compound 3: middle estimate off by 2.3-fold (0.37 log units), on the high side; the range from low to high includes it.
By their numbers in this assay, from the lowest: compounds 3, 2 and 1 (each within the scatter of the next, the first and the last beyond it).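

On this aromatic carbon, ortho to a large group, chloro in place of trifluoromethyl gives a 3.0-fold lower number from compound 1 to compound 3 (0.48 log units; beyond the scatter) in this assay. The change is modest, but it shows that the number at this position responds to the group placed there, and that 1 heavy atom can replace 4 heavy atoms with no loss of inhibition. Nothing measured here explains this step.

From the compounds shown here alone, whether a methoxy group, a nitrile or plain hydrogen on this carbon would match chloro remains open. So does whether chloro would give a similar step elsewhere on this ring.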